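The compounds below may be only part of what the source reports. "The series", "measured", "known", "first", "only" and "open" are said of these compounds alone.

Measured so far in a functional assay on U-87MG ATCC cells for antiproliferative activity against U-87 MG (Homo sapiens), read by MTT assay, with a stated time of 48 h, tested at 5 uM; a higher number here means a weaker effect of the compound at the concentration tested, a lower number a stronger effect:
compound 1 `Cc1nc(-c2ccccc2)sc1C(=O)CSc1nc(N)c(C#N)c(-c2ccc(Cl)cc2)n1`: 62.9%
compound 2 `Cc1nc(-c2ccccc2)sc1C(=O)CSc1nc(N)c(C#N)c(-c2ccccc2)n1`: 103%
compound 3 `Cc1nc(-c2ccccc2)sc1C(=O)CSc1nc(-c2ccc(Cl)cc2)c(C#N)c(=O)[nH]1`: 90.9%

Compound 2 and compound 1 share a core and differ in one place, (chloro in place of hydrogen on an aromatic carbon). In this assay the step is a number 40.1 percentage points lower from compound 2 to compound 1 (beyond the scatter). Compound 3 carries a different core; the difference between the core of compound 3 and that of compound 2 is not broken down here, and in this assay compound 3 gives 90.9%, a reading between those of compound 1 and compound 2.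

Compound 4 `Cc1nc(-c2ccc(Cl)cc2)sc1C(=O)CSc1nc(-c2ccc(Cl)cc2)c(C#N)c(=O)[nH]1` has not yet been measured. It stands to compound 3 as compound 1 stands to compound 2: chloro in place of hydrogen on an aromatic carbon. The place lines of the two differences read the same, so this is the same change on a different core.

Among the measured compounds shown here, for this assay, the step from compound 3 to compound 4 is expected to be a number 30.9 percentage points lower from compound 3 to compound 4 (beyond the scatter), resting on the one observed instance, a number 40.1 percentage points lower from compound 2 to compound 1 (beyond the scatter), but with a wider spread, since only a single example of the change exists and the core of compound 3 is not the core on which it was observed. Compound 4 is estimated at 60%, with a range from 35% to 90%.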

Compound 4, a percentage reported as activity, at one concentration (the size of the read-out at that concentration, not a potency): 99%
Compound 4: the middle estimate sits 39 percentage points below what was measured; measured number outside the range, above it.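

In this assay, the phenyl to 4-chlorophenyl change on the core of compound 3 gives a number 8.1 percentage points higher from compound 3 to compound 4 (within the scatter), so the fall in the reading seen on the core of compound 1 does not carry over to this core. The two instances of the same change disagree: the same change on two cores in this assay, a number 40.1 percentage points lower (beyond the scatter) from compound 2 to compound 1 and a number 8.1 percentage points higher (within the scatter) from compound 3 to compound 4, 48.2 percentage points apart, beyond the scatter of two such steps

This shows that in this series the step seen on one core cannot be transferred to the other, but two steps cannot show why they part, since they differ both in the core and in which of the two phenyl rings takes the chloro, and a reading at a single concentration is no potency.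

Still open, as far as these compounds go, is what the core of compound 1 gives with chloro on both phenyl rings, which would separate the role of the core from that of the ring carrying the chloro. Also open, from the compounds shown here alone, is whether a methoxy or a dimethylamino group in place of the chloro would follow either step.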